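Halogen Exchange Next to the Ring Sulfur: Chloro to Iodo

The source may report more compounds than this note shows. Statements on the series, on what has been measured and on what is new or still open speak of the compounds shown alone.

Measured so far in a functional assay on cells for agonist activity at Free fatty acid receptor 1 (Rattus norvegicus), read by FLIPR and calcium flux; on this read-out higher numbers stand for an effect only at larger amounts of compound and lower numbers for an effect already at smaller amounts:
compound 1 `CC#C[C@@H](Cc1nnn[nH]1)c1ccc(OCc2ccc3sc(F)c(-c4ccccc4C)c3c2)cc1` gives 14 nM
compound 2 `CC#C[C@@H](Cc1nnn[nH]1)c1ccc(OCc2ccc3sc(Cl)c(-c4ccccc4C)c3c2)cc1` gives 20 nM

Of the two numbers, compound 2 stands at 20 nM in this assay; the step of a 1.4-fold higher number from compound 1 to compound 2 (0.15 log units; within the scatter) lies within the scatter, so neither compound stands apart from the other. Compound 3 `CC#C[C@@H](Cc1nnn[nH]1)c1ccc(OCc2ccc3sc(I)c(-c4ccccc4C)c3c2)cc1` carries the change iodo in place of chloro on an aromatic carbon relative to compound 2. Going by the values given here, the only measured step that bears on this change is the halogen exchange from compound 1 to compound 2, a 1.4-fold higher number from compound 1 to compound 2 (0.15 log units; within the scatter), which did not move the number beyond the scatter. On that basis the step from compound 2 to compound 3 in this assay is expected to be small as well, a 1.3-fold higher number from compound 2 to compound 3 (0.10 log units; within the scatter), with no direction that can be called out beyond the scatter. Compound 3 is therefore estimated at 25 nM in this assay, with a range from 9 nM to 70 nM.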

Compound 3, half-maximal effective concentration: 33 nM
Compound 3: the middle estimate sits 1.3-fold (0.12 log units) below what was measured, and the stated range covers the measured number.
By their numbers in this assay, from the lowest: compounds 1, 2 and 3 (each within the scatter of the next, the first and the last beyond it).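

In this assay the position next to the ring sulfur takes iodo in place of chloro with a 1.7-fold higher number from compound 2 to compound 3 (0.22 log units; within the scatter) and so does not set compound 3 apart from compound 2 on this exchange alone. Across the three halogens the position is not wholly indifferent, however: iodo in place of fluoro gives a 2.4-fold higher number from compound 1 to compound 3 (0.37 log units; beyond the scatter) and is the first step at this position to pass the scatter, though only modestly. Nothing available here accounts for that difference.

Every compound shown carries a halogen at this position, so it remains open whether a halogen is needed there at all. A hydrogen, a methyl group, a nitrile or a methoxy group in its place would show whether the small shifts seen among the halogens extend to other kinds of group.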